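Changing the Aryl Group on a Shared Core

A few compounds are considered here, and "the series" means these few. Any claim that something is new, unique, unknown or untested is made for them only; others in the source may bear on it.

Compound 1, `Cc1cc(Cl)cc(-c2c(C)nn(-c3nc(-c4ccc(Cl)c(Cl)c4)c(SC(C)C)s3)c2C(=O)O)c1`: 663 nM
Compound 2, `Cc1nn(-c2nc(-c3ccc(Cl)c(Cl)c3)c(SC(C)C)s2)c(C(=O)O)c1-c1cccc(Cl)c1C`: 5100 nM
Compound 3, `COc1cc(C#N)cc(-c2c(C)nn(-c3nc(-c4ccc(Cl)c(Cl)c4)c(SC(C)C)s3)c2C(=O)O)c1`: 5200 nM

All three were tested in a functional assay on BJAB cells (Homo sapiens) for antiproliferative activity, with a stated time of 4 days; on this read-out higher numbers stand for an effect only at larger amounts of compound and lower numbers for an effect already at smaller amounts. Compound 3 gives the highest number of the three; compound 2 sits within the scatter of it, while compound 1 lies clearly lower, as the steps of a 7.7-fold higher number from compound 1 to compound 2 (0.89 log units; beyond the scatter) and a 7.8-fold higher number from compound 1 to compound 3 (0.89 log units; beyond the scatter) show. Compound 4, `Cc1nn(-c2nc(-c3ccc(Cl)c(Cl)c3)c(SC(C)C)s2)c(C(=O)O)c1-c1ccc(C(F)(F)F)cc1`, differs from compound 3 by 4-(trifluoromethyl)phenyl in place of 3-cyano-5-methoxyphenyl on an aromatic carbon. Going by the values given here, no measured step covers this new group. The two measured changes away from 3-chloro-5-methylphenyl each raised the number by a modest amount, so another change of the aryl group may move the number over a similar span, in either direction. For compound 4 the expected value is 3000 nM, with a range from 800 nM to 15000 nM. This estimate means a 1.7-fold lower number from compound 3 to compound 4 (0.24 log units; within the scatter), most likely within the scatter.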

Compound 4, half-maximal effective concentration: 3500 nM
Compound 4: middle estimate off by 1.2-fold (0.07 log units), on the low side; the measured number falls inside the stated range.
By their numbers in this assay, from the lowest: compound 1; then compounds 4, 2 and 3 (each within the scatter of the next).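

Trading 3-cyano-5-methoxyphenyl for 4-(trifluoromethyl)phenyl removes both hydrogen-bond acceptors of that group, yet the number stays within the scatter (a 1.5-fold lower number from compound 3 to compound 4 (0.17 log units; within the scatter)). The new group also lies within the scatter when set against 3-chloro-2-methylphenyl (a 1.5-fold lower number from compound 2 to compound 4 (0.16 log units; within the scatter)). The gap to 3-chloro-5-methylphenyl remains (a 5.3-fold higher number from compound 1 to compound 4 (0.72 log units; beyond the scatter)), so among these four aryl groups only that one stands apart.

Nothing available explains this grouping. Still open, from the compounds shown here alone, is how a plain phenyl, or an aryl group carrying an amine or a carboxylic acid, would compare at this position.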